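A few compounds are considered here, and "the series" means these few. Any claim that something is new, unique, unknown or untested is made for them only; others in the source may bear on it.

Of the compounds shown here, three with a shared core have been tested in an ADME assay on microsomes from liver (Homo sapiens) for metabolic stability, tested at 2.5 uM; on this read-out higher numbers stand for fast clearance and lower numbers for slow clearance. Compound 1, `COc1cccc(-c2c(S(=O)(=O)c3cccc(C#N)c3)cnc3cc(F)ccc23)c1`, gives 1.83 mL/min. Compound 2, `N#Cc1cccc(S(=O)(=O)c2cnc3cc(F)ccc3c2-c2ccccc2F)c1`, gives 1.39 mL/min, and the change from compound 1 to compound 2 is 2-fluorophenyl in place of 3-methoxyphenyl on an aromatic carbon, which gave a step of a 1.3-fold lower number from compound 1 to compound 2 (0.12 log units; within the scatter). Compound 3, `COc1cccc(-c2c(S(=O)(=O)c3ccc(F)c(F)c3)cnc3cc(F)ccc23)c1`, gives 1.77 mL/min; it differs from compound 1 by 3,4-difluorophenyl in place of 3-cyanophenyl on a sulfonyl sulfur, and the step was a 1.0-fold lower number from compound 1 to compound 3 (0.01 log units; within the scatter).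

Compound 4, `O=S(=O)(c1ccc(F)c(F)c1)c1cnc2cc(F)ccc2c1-c1ccccc1F`, has not yet been measured in this assay. Its difference from compound 3 is 2-fluorophenyl in place of 3-methoxyphenyl on an aromatic carbon, the same change that was made from compound 1 to compound 2, at the same place. The only difference between the two starting cores is the one described above between compound 1 and compound 3, which itself moved the read-out hardly at all.

For compound 4 the step from compound 3 is expected to be about a 1.3-fold lower number from compound 3 to compound 4 (0.10 log units; within the scatter), resting on the earlier step of a 1.3-fold lower number from compound 1 to compound 2 (0.12 log units; within the scatter) and on the near-equal values of compound 1 and compound 3. Compound 4 is therefore estimated at 1.4 mL/min, expected to fall between 0.9 mL/min and 2.2 mL/min.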

Compound 4, intrinsic clearance in a liver preparation (reported as CLH), per the amount of preparation that the assay uses: 0.79 mL/min
For compound 4 the middle estimate is 1.8-fold (0.25 log units) above the measured one; measured number below the stated range.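

In this assay, 2-fluorophenyl in place of 3-methoxyphenyl on an aromatic carbon gave a 2.2-fold lower number from compound 3 to compound 4 (0.35 log units; beyond the scatter), and this step cannot be told apart from the same change made earlier: the same change on two cores in this assay, a 1.3-fold lower number (0.12 log units; within the scatter) from compound 1 to compound 2 and a 2.2-fold lower number (0.35 log units; beyond the scatter) from compound 3 to compound 4, 1.7-fold (0.23 log units) apart, within the scatter of two such steps

Likewise, 3,4-difluorophenyl in place of 3-cyanophenyl on a sulfonyl sulfur gave a 1.8-fold lower number from compound 2 to compound 4 (0.25 log units; within the scatter), and again the two steps cannot be told apart: the same change on two cores in this assay, a 1.0-fold lower number (0.01 log units; within the scatter) from compound 1 to compound 3 and a 1.8-fold lower number (0.25 log units; within the scatter) from compound 2 to compound 4, 1.7-fold (0.23 log units) apart, within the scatter of two such steps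

So each change carries between these two cores with no difference that stands out from the scatter, but a single pair of steps per change does not prove that the steps are equal in size, nor that either change would act the same way on any other core.

The compounds shown leave open what an amine or a carboxylic acid on the phenyl ring at that aromatic carbon would do to the read-out. They also leave open how an alkyl chain on the sulfonyl sulfur, in place of the aromatic ring, would compare.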